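This account rests on a few compounds, and the source may have more. Where it says the series, first, only, none or still open, it means among the compounds named here.

Working notes on the series. Among the measured compounds shown here, in an ADME assay on L6 cells (Rattus norvegicus) for cytotoxicity, read by resazurin assay, with a stated time of 70 h (on this read-out lower numbers stand for stronger inhibition and higher numbers for weaker inhibition), compound 1 `Cc1ccccc1C(=O)Nc1cc(-c2ccccc2)ccn1` gives 70000 nM, the lower of the two numbers so far and clearly separated from compound 2 `Cc1c(F)cccc1C(=O)Nc1ccccn1` at 310000 nM. Compound 3 `Cc1ccccc1C(=O)Nc1cc(C#Cc2ccccc2)ccn1` departs from compound 1 at one place: 2-phenylethynyl in place of phenyl on an aromatic carbon. For the measured compounds named here, no measured pair covers this swap, so the expectation is weakly founded. The expected move in this assay is a 1.4-fold lower number from compound 1 to compound 3 (0.15 log units; within the scatter), leaning slightly toward stronger inhibition but not beyond the scatter. Compound 3 is estimated at 50000 nM, with an expected range of 20000 nM to 120000 nM.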

Compound 3, half-maximal inhibitory concentration: 198000 nM
Compound 3: middle estimate off by 4.0-fold (0.60 log units), on the low side, outside the stated range (above it).
By their numbers in this assay, from the lowest: compound 1; then compounds 3 and 2 (each within the scatter of the next).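

In this assay, among the compounds shown here, 2-phenylethynyl in place of phenyl on the aromatic carbon opposite the ring nitrogen gives a 2.8-fold higher number from compound 1 to compound 3 (0.45 log units; beyond the scatter) and so goes with weaker inhibition, a direction the earlier compounds could not show at this position. This rests on a single pair and says nothing about other positions. Nothing at hand accounts for the shift.

Still open, going by these compounds, is whether the triple bond or the terminal phenyl carries this step. An amine or a carboxylic acid at this position also remains untested in the compounds shown here.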